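Nitro in Place of Methyl: Expectation for Compound 4

The compounds below may be only part of what the source reports. "The series", "measured", "known", "first", "only" and "open" are said of these compounds alone.

Three compounds have been measured in a functional assay on the whole organism (Hindlimb, strain albino) with Mus musculus as the target, in the maximal electroshock model, with a stated time of 0.5 h; on this read-out lower numbers stand for an effect already at smaller amounts and higher numbers for an effect only at larger amounts of compound:

Compound 1, `O=C(/C=C/c1ccccc1)Nc1nc2ccc([N+](=O)[O-])cc2s1`: 485 umol/kg
Compound 2, `CC(=O)N1N=C(Nc2nc3ccc(C)cc3s2)CC1c1ccc(Cl)cc1`: 25.5 umol/kg
Compound 3, `Cc1ccc2nc(NC(=O)/C=C/c3ccccc3)sc2c1`: 380 umol/kg

Compounds 1 and 3 share one core and differ in a single place: nitro in place of methyl on an aromatic carbon. That change gives a 1.3-fold higher number from compound 3 to compound 1 (0.11 log units; within the scatter). Compound 2 carries a different core; how its core differs from that of compound 3 is not broken down here. In this assay compound 2 gives the lowest number of the three, and its separation from both compound 3 and compound 1 is beyond the scatter.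

Compound 4, `CC(=O)N1N=C(Nc2nc3ccc([N+](=O)[O-])cc3s2)CC1c1ccc(Cl)cc1`, has not yet been measured. It differs from compound 2 by nitro in place of methyl on an aromatic carbon, which is the same change as that from compound 3 to compound 1. The step expected in this assay is a 1.3-fold higher number from compound 2 to compound 4 (0.10 log units; within the scatter), and this expectation rests on the earlier step of a 1.3-fold higher number from compound 3 to compound 1 (0.11 log units; within the scatter). For compound 4 the estimated value in this assay is 32 umol/kg, with the likely range running from 14 umol/kg to 75 umol/kg.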

Compound 4, dose for half-maximal effect: 132 umol/kg
The estimate for compound 4 lay 4.1-fold (0.62 log units) below the measured number; measured number above the stated range.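

In this assay nitro in place of methyl on an aromatic carbon gives a 5.2-fold higher number from compound 2 to compound 4 (0.71 log units; beyond the scatter) and so does not repeat on this core the step seen on the other, the two steps being clearly apart: the same change on two cores in this assay, a 1.3-fold higher number (0.11 log units; within the scatter) from compound 3 to compound 1 and a 5.2-fold higher number (0.71 log units; beyond the scatter) from compound 2 to compound 4, 4.1-fold (0.61 log units) apart, beyond the scatter of two such steps.

This shows that, across these two pairs, the size of the step depends on the core it is made on, so a step read on one core cannot simply be carried over to the other. It does not show which part of the cores accounts for the gap, and two pairs give no rule for any further core in the series.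

The compounds shown carry only methyl or nitro at this aromatic carbon, so it stays open how an amine, a methoxy group or fluorine would behave there on either core. Also open, on these data alone, is how the number would move on the core shared by compound 2 and compound 4 if a methoxy group took the place of the chlorine.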